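A few compounds are considered here, and "the series" means these few. Any claim that something is new, unique, unknown or untested is made for them only; others in the source may bear on it.

In a functional assay on GC-2 cells (Mus musculus) for cytotoxicity, read by MTT assay, with a stated time of 72 h (a higher number here means a weaker inhibitor, a lower number a stronger inhibitor), compound 3 `Nc1nc(Nc2ccc(S(N)(=O)=O)cc2)sc1C(=O)c1cccnc1` gives > 30000 nM, which is a limit and not a number. This is the limit of > 30000 nM in this assay, at which 1 of the 3 values shown sits. Compound 4 `Nc1nc(Nc2ccc(S(N)(=O)=O)cc2)sc1C(=O)c1cccc([N+](=O)[O-])c1` replaces pyridin-3-yl on a carbonyl carbon with 3-nitrophenyl: 3-nitrophenyl in place of pyridin-3-yl on a carbonyl carbon. The closest measured exchange is 3-fluorophenyl in place of pyridin-3-yl. There, compound 1 `Nc1nc(Nc2ccccc2)sc1C(=O)c1cccnc1` gives 9500 nM and compound 2 `Nc1nc(Nc2ccccc2)sc1C(=O)c1cccc(F)c1` gives 4100 nM, which is a 2.3-fold lower number from compound 1 to compound 2 (0.36 log units; beyond the scatter). The sulfamoyl step, an at least 3.1-fold higher number from compound 1 to compound 3 (0.49 log units; beyond the scatter), shows that compound 3 starts from the weak end of the series. Going by the values given here, no measured compound carries 3-nitrophenyl, so a modest shift toward lower numbers is expected, and it may stay near the limit. The expected change is an at least 1.5-fold lower number from compound 3 to compound 4 (0.17 log units; that floor lies within the scatter). For compound 4 the estimated value is 20000 nM, with an expected range of 7000 nM to 60000 nM.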

Compound 4, half-maximal inhibitory concentration: 20000 nM
For compound 4 middle estimate and measured number coincide at the digits printed; the measured number falls inside the stated range.
By their numbers in this assay, from the lowest: compound 2; then compound 1; then compound 4. At a limit, above all of these: compound 3.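

In this assay compound 3 has only a limit, and it is not a number: the limit of > 30000 nM in this assay, at which 1 of the 4 values shown sits.

Compound 4 gives the sulfamoyl pair a measured value, and the step is an at least 1.5-fold lower number from compound 3 to compound 4 (0.17 log units; that floor lies within the scatter). The exchange on the carbonyl carbon thus points the same way with sulfamoyl present as in a 2.3-fold lower number from compound 1 to compound 2 (0.36 log units; beyond the scatter), though the floor of the new step does not clear the scatter.

As far as these compounds go, the true size of the new step stays open while compound 3 rests on a limit. Also open, from the compounds shown here alone, is what an amine or a carboxylic acid would give on the aromatic carbon that carries sulfamoyl.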